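The source may report more compounds than this note shows. Statements on the series, on what has been measured and on what is new or still open speak of the compounds shown alone.

In a functional assay on LoVo cells (Homo sapiens) for cytotoxicity, read by MTT assay, with a stated time of 72 h (on this read-out higher numbers stand for weaker inhibition and lower numbers for stronger inhibition), compound 1 `O=C(Nc1ccc(-n2ncc3c(F)cccc32)cc1)Nc1ccc(Cl)c(C(F)(F)F)c1` gives 9800 nM and compound 2 `O=C(Nc1ccc(-n2ncc3cnccc32)cc1)Nc1ccc(Cl)c(C(F)(F)F)c1` gives 8000 nM. Of the two numbers shown, that of compound 2 is the smaller, but the difference from compound 1 lies within the scatter, so the two cannot be separated. For the measured compounds named here, the only measured step, a 1.2-fold lower number from compound 1 to compound 2 (0.09 log units; within the scatter), exchanged a six-membered aromatic ring of carbon only, with fluorine, for a six-membered aromatic ring with one hetero atom and stayed within the scatter. Compound 3 `O=C(Nc1ccc(-n2ncc3ccncc32)cc1)Nc1ccc(Cl)c(C(F)(F)F)c1` has the same atoms as compound 2 joined differently: a group of 9 heavy atoms (6 carbon, 3 nitrogen; one five-membered aromatic ring with 2 hetero atoms, one six-membered aromatic ring with 1 hetero atom) in place of a group of 9 heavy atoms (6 carbon, 3 nitrogen; one five-membered aromatic ring with 2 hetero atoms, one six-membered aromatic ring with 1 hetero atom), on an aromatic carbon. Going by the values given here, this is a shift of the hetero atom within the six-membered aromatic ring with 1 hetero atom; no measured step tests such a shift, and the one step that touched this group moved nothing beyond the scatter. In this assay no step beyond the scatter is expected from compound 2 to compound 3, no change at the digits printed from compound 2 to compound 3 (within the scatter). Compound 3 is therefore expected to give 8000 nM, with a range of 3000 nM to 22000 nM.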

Compound 3, half-maximal inhibitory concentration: 7100 nM
For compound 3 the middle estimate is 1.1-fold (0.05 log units) above the measured one; measured number inside the range.
By their numbers in this assay, from the lowest: compounds 3, 2 and 1 (each within the scatter of the next).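

In this assay, the shift of the hetero atom within the six-membered aromatic ring with 1 hetero atom gives a 1.1-fold lower number from compound 2 to compound 3 (0.05 log units; within the scatter), the first measured read on such a shift, and the two isomers cannot be separated. The exchange of the fluorine-bearing, carbon-only ring for this second isomer gives a 1.4-fold lower number from compound 1 to compound 3 (0.14 log units; within the scatter), so neither placement of the ring nitrogen is distinguished from the fluorine compound. No evidence is available that bears on this result. On these data alone, it remains open whether an added group on this six-membered ring, such as an amine or a carboxylic acid, would move the number beyond the scatter. It also remains open whether the lack of separation among these three compounds would hold on another cell line.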